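Trifluoromethyl for chloro on the benzyl arm

This account rests on a few compounds, and the source may have more. Where it says the series, first, only, none or still open, it means among the compounds named here.

Measured compounds:
Compound 1 `CCNc1nc(-c2ccccc2)nc2c1nnn2Cc1ccccc1C(F)(F)F` — "not determined" (no result reported) in this assay.
Compound 2 `CCCCNc1nc(-c2ccccc2)nc2c1nnn2Cc1ccccc1C(F)(F)F` — 6.5 nM in this assay.
Compound 3 `Clc1ccccc1Cn1nnc2c(NC3CC3)nc(-c3ccccc3)nc21` — 11 nM in this assay.

The series shares one core and varies the amine on one side and the substituted benzyl group on the other. In an assay on Cerebral cortex for displacement of a labelled ligand from adenosine receptor A1 (Bos taurus) (a lower number here means a stronger inhibitor, a higher number a weaker inhibitor), compound 2 gives 6.5 nM, and compound 3 gives 11 nM. Going by the values given here, compound 3 thus holds the higher of the two numbers known, but its nearest neighbour, compound 2, sits within the usual scatter of repeated measurements, so the two cannot be ranked against each other. For compound 1 the entry in this assay reads "not determined" (no result reported).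

Compound 4 `FC(F)(F)c1ccccc1Cn1nnc2c(NC3CC3)nc(-c3ccccc3)nc21` has not yet been measured. It keeps the cyclopropylamino group of compound 3 and changes the benzyl substituent: trifluoromethyl in place of chloro on an aromatic carbon. The same trifluoromethyl-bearing benzyl group is already present in compound 2, which carries a butylamino group instead and gives 6.5 nM in this assay. Among the compounds with values here, no pair of measured compounds isolates this single change, so no measured step guides the expectation directly.

On the numbers at hand, the step from compound 3 to compound 4 is expected to be small, a 1.4-fold lower number from compound 3 to compound 4 (0.14 log units; within the scatter), and not to reach beyond the scatter in either direction. Compound 4 is therefore estimated at 8 nM, with a range from 3 nM to 25 nM.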

Compound 4, inhibition constant: 7.8 nM
Beside the measured number, compound 4's estimate is 1.0-fold (0.01 log units) above it; measured number inside the range.
By their numbers in this assay, from the lowest: compounds 2, 4 and 3 (each within the scatter of the next).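

With compound 4, this position has its first comparison that changes one place only: in this assay, trifluoromethyl in place of chloro on an aromatic carbon, ortho to a large group, gives a 1.4-fold lower number from compound 3 to compound 4 (0.15 log units; within the scatter). The 2-chlorophenyl and 2-(trifluoromethyl)phenyl arms therefore cannot be told apart here on the cyclopropylamino compounds, even though the entering group has 4 heavy atoms and the leaving group 1. Compound 4 also connects the series on the amine side, where cyclopropyl in place of butyl on a nitrogen on an aromatic ring gives a 1.2-fold higher number from compound 2 to compound 4 (0.08 log units; within the scatter), so these two amines cannot be told apart with the trifluoromethyl-bearing arm, and nothing shown gives a reason for either step.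

The compounds shown leave open what a methoxy group or a plain hydrogen would give on this aromatic carbon. They also leave open whether the two benzyl arms would remain indistinguishable with butylamino, or with a cyclic amine such as piperidine, in place of cyclopropylamino on the shared core.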